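Swapping a Ring Amine for an Open-Chain Amine

This account rests on a few compounds, and the source may have more. Where it says the series, first, only, none or still open, it means among the compounds named here.

Compound 1, `NCCNC(=S)Nc1ccnc2cc(Cl)ccc12`, gives 18000 nM in a functional assay on HeLa cells (Homo sapiens) for cytotoxicity, read by MTT assay, with a stated time of 7 h; on this read-out higher numbers stand for weaker inhibition and lower numbers for stronger inhibition.
Compound 2, `S=C(Nc1ccnc2cc(Cl)ccc12)N1CCNCC1`, gives "not determined" (no result reported) in this assay.

Compound 2 therefore stands nowhere on the numbers: no result was reported for it, so it has no value to build on. Compound 3, `CN(C)CCCNC(=S)Nc1ccnc2cc(Cl)ccc12`, is its open-chain counterpart; the change is (3-(dimethylamino)propyl)amino in place of piperazin-1-yl on a thiocarbonyl carbon. Among the compounds with values here, no step between two measured compounds is available here, so nothing shows how large a shift such a change brings in this assay, or in which direction. Within the data shown here, the one number at hand comes from compound 1, which gives 18000 nM, a weak figure on this read-out. Given that compound 1 gives 18000 nM, compound 3 is expected to land in the same weak region, with an estimate of 15000 nM and a likely range from 4000 nM to 60000 nM, held loosely.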

Compound 3, half-maximal inhibitory concentration: 48500 nM
Compound 3: middle estimate off by 3.2-fold (0.51 log units), on the low side, and the stated range covers the measured number.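

Within the data shown here, the first measured step in this set comes from the open-chain compounds: in this assay, (dimethylamino)methyl in place of amino on a saturated chain carbon gives a 2.7-fold higher number from compound 1 to compound 3 (0.43 log units; beyond the scatter). A higher number here means weaker inhibition, and this modest step, beyond the usual scatter, therefore points towards weaker inhibition for this change on the chain. Compound 2 has no number, and the steps that would compare it with the open-chain compounds, including the swap of piperazin-1-yl for (3-(dimethylamino)propyl)amino, cannot be read. Nothing available explains the direction or the size of this step. Still open, going by these compounds, is where a methylamino group at the end of the same chain would fall relative to compound 1 and compound 3. Also open, on these data alone, is whether a longer chain ending in dimethylamino would move the number further.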